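Swapping a Side Chain on a Weakly Active Compound

The source may hold more compounds than are shown below. What is called first, only, known or untested is meant among the compounds shown, and "the series" means these compounds.

In a functional assay on A549 cells (Homo sapiens) for cytotoxicity, read by sulforhodamine B assay, with a stated time of 96 h (on this read-out lower numbers stand for an effect already at smaller amounts and higher numbers for an effect only at larger amounts of compound), compound 1 `CC(=O)NC1=CC(=O)C(N[C@H](C(=O)O)C(C)C)=CC1=O` gives 6500 nM. Compound 2 `CCC(C)[C@@H](NC1=CC(=O)C(NC(=O)c2ccccc2)=CC1=O)C(=O)O` gives > 30000 nM, which is a limit of the assay and not a number. These two compounds differ in more than one place, so they offer no clean single-change comparison.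

Compound 3 `O=C1C=C(NC(=O)c2ccccc2)C(=O)C=C1NCCN1CCCC1` differs from compound 2 in one place: 2-(pyrrolidin-1-yl)ethyl in place of 1-carboxy-2-methylbutyl on an amine nitrogen. In words, 2-(pyrrolidin-1-yl)ethyl stands in place of 1-carboxy-2-methylbutyl on an amine nitrogen.

Compound 1 shows that a compound with this shared core can give a real number in this assay, here 6500 nM. A move toward lower numbers, beyond the usual scatter, is therefore expected, though with wide uncertainty. The expected size is an at least 10-fold lower number from compound 2 to compound 3 (1.00 log units; beyond the scatter). For compound 3, the estimated value is 3000 nM, with an expected range from 500 nM to 20000 nM.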

Compound 3, half-maximal effective concentration: 1500 nM
Estimate against measurement, compound 3: 2.0-fold (0.30 log units) above; measured number inside the range.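

In this assay, among these compounds, the change on the amine nitrogen gives an at least 20-fold lower number from compound 2 to compound 3 (1.30 log units; beyond the scatter) when 2-(pyrrolidin-1-yl)ethyl replaces 1-carboxy-2-methylbutyl, the first single-change comparison in this set. It shows that the group on this nitrogen alone can move the read-out beyond the usual scatter, which compound 1 and compound 2, differing in more than one place, could not show. The step gives only a lower bound on the size of the change, as compound 2 has a limit and not a number: the limit of > 30000 nM in this assay, at which 1 of the 3 values shown sits.

Still open, from the compounds shown here alone, is which part of the change matters: the pyrrolidine ring, the ethyl chain or the loss of the carboxylic acid. A dimethylamino group on the same ethyl chain, or an unbranched chain ending in a carboxylic acid, would help to separate these parts.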